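The source may hold more compounds than are shown below. What is called first, only, known or untested is meant among the compounds shown, and "the series" means these compounds.

Compound 1, `COc1ccc(-c2nnc(SCCCN3CCN(c4nc5ccccc5s4)CC3)o2)cc1`, gives 165000 nM in a functional assay on HeLa cells (Homo sapiens) for inhibition, read by MTT assay, with a stated time of 72 h; on this read-out higher numbers stand for weaker inhibition and lower numbers for stronger inhibition. Compound 2, `Cc1ccc(-c2nnc(SCCCN3CCN(c4nc5ccccc5s4)CC3)o2)cc1`, gives 179000 nM in this assay. Compound 3, `Fc1ccc(-c2nnc(SCCCN3CCN(c4nc5ccccc5s4)CC3)o2)cc1`, gives 134000 nM in this assay.

Compound 3 has the lowest of the three numbers, but the steps of a 1.2-fold lower number from compound 1 to compound 3 (0.09 log units; within the scatter) and a 1.3-fold lower number from compound 2 to compound 3 (0.13 log units; within the scatter) both fall within the scatter, as does a 1.1-fold higher number from compound 1 to compound 2 (0.04 log units; within the scatter), so the three compounds cannot be told apart on these data.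

Compound 4, `Oc1ccc(-c2nnc(SCCCN3CCN(c4nc5ccccc5s4)CC3)o2)cc1`, differs from compound 3 in one place: hydroxy in place of fluoro on an aromatic carbon. Among the compounds with values here, none of the measured steps brings in a hydroxy group; the closest measured swaps exchange methoxy, methyl and fluoro at this same aromatic carbon, and every one of them stayed within the scatter. On that basis the step of a 1.1-fold higher number from compound 3 to compound 4 (0.05 log units; within the scatter) in this assay is expected to lie within the scatter as well, with no clear direction. Compound 4 is therefore estimated at 150000 nM in this assay, with a range from 70000 nM to 320000 nM.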

Compound 4, half-maximal inhibitory concentration: 139000 nM
Estimate against measurement, compound 4: 1.1-fold (0.03 log units) above, within the range that was stated.
By their numbers in this assay, from the lowest: compounds 3, 4, 1 and 2 (each within the scatter of the next).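

In this assay, within the data shown here, the hydroxy group brings the first hydrogen-bond donor to this position, yet no step to it can be told from the scatter: a 1.0-fold higher number from compound 3 to compound 4 (0.02 log units; within the scatter), a 1.3-fold lower number from compound 2 to compound 4 (0.11 log units; within the scatter) and a 1.2-fold lower number from compound 1 to compound 4 (0.07 log units; within the scatter). Among these four compounds, then, a group with a donor at this aromatic carbon reads the same as fluoro, methyl or methoxy, and taking the methyl off the methoxy oxygen leaves the number where it was. No measurement is available that would account for this flat response.

On these data alone, it remains open whether any group at this position can move the number clear of the scatter, such as an amine, a carboxylic acid or a longer alkoxy chain. Also open, as far as these compounds go, is whether changes elsewhere in the shared core would do so.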